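The source may report more compounds than this note shows. Statements on the series, on what has been measured and on what is new or still open speak of the compounds shown alone.

Four compounds share one core and are compared in an assay on BTI cells for inhibition of Amine oxidase [flavin-containing] B (Homo sapiens), read by fluorescence, with stated times of 30 min and 1 h, tested at 1 uM; on this read-out higher numbers stand for more inhibition at the one concentration tested (going by the name of the read-out) and lower numbers for less inhibition. Compound 1, `C#CCN(C)Cc1ccc(OCCCCN2CCN(c3cccc4c3ccn4Cc3cccc(Cl)c3)CC2)cc1`, gives 85% in this assay. Compound 2, `C#CCN(C)Cc1ccc(OCCCCCN2CCN(c3cccc4c3ccn4Cc3cccc(Cl)c3)CC2)cc1`, gives 100%, the highest of the three measured numbers. How the core of compound 2 differs from that of compound 1 is not broken down here. Compound 3, `C#CCN(C)Cc1ccc(OCCCCN2CCN(c3cccc4c3ccn4S(=O)(=O)c3ccccc3)CC2)cc1`, gives 51%.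

Compound 3 arises from compound 1 by one change, (phenylsulfonyl in place of 3-chlorobenzyl on an aromatic nitrogen), and this step is a number 34 percentage points lower from compound 1 to compound 3 (beyond the scatter). Compound 4, `C#CCN(C)Cc1ccc(OCCCCCN2CCN(c3cccc4c3ccn4S(=O)(=O)c3ccccc3)CC2)cc1`, has not yet been measured; it arises from compound 2 by the change (phenylsulfonyl in place of 3-chlorobenzyl on an aromatic nitrogen), which is the same change, made at the same place, as the one from compound 1 to compound 3, so it occurs twice among these compounds.

For compound 4 the expectation rests on that single earlier step. Since the same change once lowered the number in this assay by the amount given in a number 34 percentage points lower from compound 1 to compound 3 (beyond the scatter), a step of about a number 30 percentage points lower from compound 2 to compound 4 (beyond the scatter) from compound 2 to compound 4 is expected, with the caution that compound 2 already sits at the top of what the read-out can show, so the true drop may be smaller than the earlier one. Compound 4 is therefore estimated at 70%, most likely between 50% and 90%.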

Compound 4, a percentage reported as inhibition, at one concentration (the size of the read-out at that concentration, not a potency): 91%
Compound 4: middle estimate off by 21 percentage points, on the low side; measured number outside the range, above it.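

In this assay, putting phenylsulfonyl in place of 3-chlorobenzyl on the aromatic nitrogen gives a different result here: the step is a number 9 percentage points lower from compound 2 to compound 4 (within the scatter). Going by these compounds alone, this change therefore cannot be carried from one core to the other as a fixed step, since its size on the core of compound 1 did not predict its size on the core of compound 2: the same change on two cores in this assay, a number 34 percentage points lower (beyond the scatter) from compound 1 to compound 3 and a number 9 percentage points lower (within the scatter) from compound 2 to compound 4, 25 percentage points apart, beyond the scatter of two such steps This rests on only two pairs at a single concentration, with percentages that are not potencies, and compound 2, at 100%, stands at the top of what the read-out can show, so the result does not explain the difference between the steps or show how the change would behave on a third core.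

The compounds shown leave open how other groups on that aromatic nitrogen, such as a simple methyl or an acetyl, would compare with 3-chlorobenzyl and phenylsulfonyl on these two cores. They also leave open whether the step would stay this small with a longer chain, and how the pairs would compare if tested at lower concentrations, where a reading at the top of the scale would be less of a limit.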